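A few compounds are considered here, and "the series" means these few. Any claim that something is new, unique, unknown or untested is made for them only; others in the source may bear on it.

In a functional assay on a cell-free system (plasma, Oryctolagus cuniculus) for inhibition, with stated times of 5 min, 1 min and 6 min (a higher number here means a weaker inhibitor, a lower number a stronger inhibitor), compound 1 `CCOC(=O)c1c(C)nc(-c2cccc(C#N)c2)n1C` gives 22100 nM, compound 2 `CCOC(=O)c1c(C)nc(-c2cccc(C#N)c2)n1OCc1ccccc1` gives 5930 nM and compound 3 `CCOC(=O)c1c(C)nc(-c2cccc(C#N)c2)n1OCc1ccc(F)cc1` gives 5880 nM. Compound 3 thus sits level with compound 2, and the gap on the other side is a 3.8-fold lower number from compound 1 to compound 3 (0.58 log units; beyond the scatter). Compound 4 `CCOC(=O)c1c(C)nc(-c2cccc(C#N)c2)n1OCc1ccc(Br)cc1` carries bromo in place of fluoro on an aromatic carbon, para to a large group: bromo in place of fluoro on an aromatic carbon. Going by the values given here, the only measured change on that carbon, fluoro in place of hydrogen, is a 1.0-fold lower number from compound 2 to compound 3 (0.00 log units; within the scatter), within the scatter. The larger 3.7-fold lower number from compound 1 to compound 2 (0.57 log units; beyond the scatter) concerns a different place. No step beyond the scatter is therefore expected in this assay, the expected change being a 1.1-fold lower number from compound 3 to compound 4 (0.03 log units; within the scatter). The estimate for compound 4 is 5500 nM, with an expected range from 2500 nM to 12000 nM.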

Compound 4, half-maximal inhibitory concentration: 24600 nM
For compound 4 the middle estimate is 4.5-fold (0.65 log units) below the measured one; the measured number lies above the stated range.
By their numbers in this assay, from the lowest: compounds 3 and 2 (each within the scatter of the next); then compounds 1 and 4 (each within the scatter of the next).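

In this assay this aromatic carbon, para to a large group, proved sensitive to the choice of substituent: bromo in place of fluoro gave a real loss (a 4.2-fold higher number from compound 3 to compound 4 (0.62 log units; beyond the scatter)), and bromo in place of hydrogen gave much the same (a 4.1-fold higher number from compound 2 to compound 4 (0.62 log units; beyond the scatter)). Fluoro in place of hydrogen had shown no such effect. The (4-bromobenzyl)oxy group also leaves compound 4 level with the methyl compound (a 1.1-fold higher number from compound 1 to compound 4 (0.05 log units; within the scatter)), and nothing available explains this result. As far as these compounds go, it remains open whether chloro or iodo on this carbon would track fluoro or bromo, and whether a methyl or methoxy group there would behave like bromo.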